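Moving the Methylpiperidine Attachment Point on a Shared Core

This account rests on a few compounds, and the source may have more. Where it says the series, first, only, none or still open, it means among the compounds named here.

Of the compounds shown here, three sharing one core have been tested in an assay on HEK293 cells for inhibition of acid ceramidase (Homo sapiens), read by fluorescence, with stated times of 10 min and 3 h; on this read-out higher numbers stand for weaker inhibition and lower numbers for stronger inhibition. Compound 1 `CN1CCC(c2ccc3c(c2)oc(=O)n3C(=O)NCCCCc2ccc(F)cc2)CC1` gives 94 nM, the lowest number of the three. Compound 2 `CCC(C)NC(=O)n1c(=O)oc2cc(C3CCN(C)CC3)ccc21` gives 2100 nM, the highest. Compound 3 `CC(C)CNC(=O)n1c(=O)oc2cc(C3CCCCN3C)ccc21` gives 1010 nM, which is the second highest of the three numbers; compound 2 stands nearest to it and compound 1 furthest, both differences lying beyond the usual scatter.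

The next compound, compound 4 `CC(C)CNC(=O)n1c(=O)oc2cc(C3CCN(C)CC3)ccc21`, has the same atoms as compound 3 joined differently: 1-methylpiperidin-4-yl in place of 1-methylpiperidin-2-yl on an aromatic carbon. Among the measured compounds shown here, the isobutyl side chain of compound 3 is kept, so the only change is how the methylpiperidine ring is attached to the aromatic carbon.

For the measured compounds named here, no pair of measured compounds differs at this one place alone, so the size of the step is uncertain. Compound 4 carries the same 1-methylpiperidin-4-yl group as compound 2, which gives 2100 nM, while compound 1, also with that group but a longer side chain, gives 94 nM. The expected step is small, toward a somewhat higher number, and may well lie within the scatter: a 1.5-fold higher number from compound 3 to compound 4 (0.17 log units; within the scatter). Compound 4 is therefore estimated at 1500 nM, with a likely range from 500 nM to 4500 nM.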

Compound 4, half-maximal inhibitory concentration: 166 nM
Estimate against measurement, compound 4: 9.0-fold (0.96 log units) above; measured number below the stated range.
By their numbers in this assay, from the lowest: compounds 1 and 4 (each within the scatter of the next); then compound 3; then compound 2.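

In this assay, the attachment point of the methylpiperidine ring matters on its own: with the isobutyl side chain kept, 1-methylpiperidin-4-yl in place of 1-methylpiperidin-2-yl on the aromatic carbon gives a 6.1-fold lower number from compound 3 to compound 4 (0.78 log units; beyond the scatter). The side chain is just as sensitive to a small rearrangement, as isobutyl in place of sec-butyl on the amide-type nitrogen, with the 1-methylpiperidin-4-yl group held fixed, gives a 13-fold lower number from compound 2 to compound 4 (1.10 log units; beyond the scatter). The long chain of compound 1 also turns out to offer no measurable advantage here, because isopropyl in place of 3-(4-fluorophenyl)propyl on the saturated chain carbon gives a 1.8-fold higher number from compound 1 to compound 4 (0.25 log units; within the scatter), so these two compounds cannot be told apart in this assay.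

No measurement among these compounds accounts for the size of either large step. Still open, on these data alone, is whether the ring needs its methyl group at all, as a plain piperidine or a morpholine would test, and whether an unbranched butyl chain on the amide-type nitrogen would fit the same trend.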